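Chain-end change from hydroxycarbamoyl to methylcarbamoylmethyl

The source may hold more compounds than are shown below. What is called first, only, known or untested is meant among the compounds shown, and "the series" means these compounds.

Compound 2 `CC(C)c1cc(-c2n[nH]c(=O)n2-c2cccc(C(=O)NCCCCCCC(=O)NO)c2)c(O)cc1O` gives 4600 nM in a functional assay on A549 cells (Homo sapiens) for inhibition (on this read-out higher numbers stand for weaker inhibition and lower numbers for stronger inhibition), level with compound 1 `CC(C)c1cc(-c2n[nH]c(=O)n2-c2cccc(C(=O)NCCCC(=O)NO)c2)c(O)cc1O`, which gives 4600 nM; the step of no change at the digits printed from compound 1 to compound 2 (within the scatter) shows no change beyond the scatter. Compound 3 `CNC(=O)CCCCCCCNC(=O)c1cccc(-n2c(-c3cc(C(C)C)c(O)cc3O)n[nH]c2=O)c1` differs from compound 2 by (methylcarbamoyl)methyl in place of hydroxycarbamoyl on a saturated chain carbon, six bonds along the chain from an amide-type nitrogen. Within the data shown here, neither measured step touches the hydroxycarbamoyl group itself, so no measured step bears directly on this change; the only measured step concerns chain length alone. Compound 3 is therefore expected to give 20000 nM, within 4000 nM to 100000 nM, a step of a 4.3-fold higher number from compound 2 to compound 3 (0.64 log units; beyond the scatter) toward weaker inhibition.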

Compound 3, half-maximal inhibitory concentration: 4600 nM
Estimate against measurement, compound 3: 4.3-fold (0.64 log units) above; the range from low to high includes it.
By their numbers in this assay, from the lowest: compounds 1, 2 and 3 (each within the scatter of the next).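

In this assay, (methylcarbamoyl)methyl in place of hydroxycarbamoyl on the saturated chain carbon gives no change at the digits printed from compound 2 to compound 3 (within the scatter), so among these compounds the hydroxycarbamoyl end is not needed to hold this level. The wider change, 4-(methylcarbamoyl)butyl in place of hydroxycarbamoyl, gives no change at the digits printed from compound 1 to compound 3 (within the scatter). Nothing given here accounts for this result.

The three compounds leave open whether a carboxylic acid or an amine at the chain end would read the same way. They also leave open whether a longer chain would alter the number.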